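The source may hold more compounds than are shown below. What is called first, only, known or untested is meant among the compounds shown, and "the series" means these compounds.

Three compounds were measured in a functional assay on SMMC-7721 cells (Homo sapiens) for inhibition, read by MTT assay, with a stated time of 72 h, tested at 1 uM; on this read-out higher numbers stand for a stronger effect at the one concentration tested and lower numbers for a weaker effect:

compound 1, `Cc1cccc2ncnc(O/N=C(\C=C\c3ccccn3)/C=C/c3ccccc3OCc3ccc(Cl)cc3Cl)c12`: 90.8%
compound 2, `Clc1ccccc1COc1ccc(/C=C/C(/C=C/c2ccccn2)=N/Oc2ncnc3ccccc23)cc1`: 10.1%
compound 3, `Clc1ccc(COc2ccccc2/C=C/C(/C=C/c2ccccn2)=N/Oc2ncnc3ccccc23)c(Cl)c1`: 33.3%

Compound 1 and compound 3 differ in one place, (methyl in place of hydrogen on an aromatic carbon), and this change brought a number 57.5 percentage points higher from compound 3 to compound 1 (beyond the scatter). Compound 2 stands lowest of the three; the difference between the core of compound 2 and the core of compound 3 is not broken down here, so the two values are only compared as they stand.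

Compound 4, `Cc1cccc2ncnc(O/N=C(/C=C/c3ccc(OCc4ccccc4Cl)cc3)\C=C\c3ccccn3)c12`, is not yet measured. It differs from compound 2 by methyl in place of hydrogen on an aromatic carbon, and the place of this change reads the same as the place of the change from compound 3 to compound 1, so the same change is made a second time. For the measured compounds named here, since compound 2 starts from 10.1%, a step of a number 39.9 percentage points higher from compound 2 to compound 4 (beyond the scatter) is expected in this assay, resting on the single earlier case a number 57.5 percentage points higher from compound 3 to compound 1 (beyond the scatter) and on nothing else. For compound 4 the estimate is 50%, between 20% and 85%.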

Compound 4, a percentage reported as inhibition, at one concentration (the size of the read-out at that concentration, not a potency): 77%
Beside the measured number, compound 4's estimate is 27 percentage points below it, within the range that was stated.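

In this assay, methyl in place of hydrogen on an aromatic carbon, which turns quinazolin-4-yl into 5-methylquinazolin-4-yl, gave a number 66.9 percentage points higher from compound 2 to compound 4 (beyond the scatter) and so kept its large size on a second core. The two cases agree as far as the scatter allows: the same change on two cores in this assay, a number 57.5 percentage points higher (beyond the scatter) from compound 3 to compound 1 and a number 66.9 percentage points higher (beyond the scatter) from compound 2 to compound 4, 9.4 percentage points apart, within the scatter of two such steps. For the compounds shown here, this shows that, in these two pairs, the size of the step did not visibly depend on which of the two cores carried it, but it rests on only two pairs, in one cell line and at one concentration, so it gives no potency and sets no rule for other cores.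

The compounds shown leave open whether this step belongs to methyl as such, since nothing here tells how an ethyl, a methoxy or a chlorine in its place would read. They also leave open whether a 5-methylquinazolin-4-yl group would bring a similar step if the chlorinated benzyl ether gave way to an amine such as morpholine.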